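The compounds below may be only part of what the source reports. "The series", "measured", "known", "first", "only" and "open" are said of these compounds alone.

Of the compounds shown here, three have so far been measured in an assay on COS-7 cells for inhibition of patatin-like phospholipase domain-containing protein 2 (Mus musculus); on this read-out higher numbers stand for weaker inhibition and lower numbers for stronger inhibition. Compound 1 `CCOC(=O)c1cccc(-c2cccs2)c1` gives 90000 nM in this assay. Compound 2 `CCOC(=O)c1cccc(-c2ccc(OCC)c([N+](=O)[O-])c2)c1` gives 200000 nM. Compound 3 `CCOc1ccc(-c2cccc(S(=O)(=O)N(C)C)c2)cc1` gives 110000 nM, the second highest of the three numbers; its gap to compound 1 and its gap to compound 2 both lie within the usual scatter of repeated measurements, so none of the three can be set apart from the others, and all three are weak inhibitors.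

Compound 4 `CCOc1ccc(-c2cccc([N+](=O)[O-])c2)cc1` has not yet been measured. It differs from compound 3 in one place: nitro in place of dimethylsulfamoyl on an aromatic carbon. Among the compounds with values here, no step between two measured compounds differing in a single place is known here, so the expectation rests on the weak values of all three measured compounds. Compound 2, which also carries a nitro on an aromatic ring, gives 200000 nM, a number within the scatter of compound 3. The step expected here, a 1.4-fold higher number from compound 3 to compound 4 (0.13 log units; within the scatter), is therefore none beyond the scatter. Compound 4 is expected to give 150000 nM, in a range from 60000 nM to 400000 nM.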

Compound 4, half-maximal inhibitory concentration: > 200000 nM
Compound 4: only a limit was reported; the forecaster's own chance of this, stated with the estimate: 30%; at least 1.3-fold (0.12 log units) between middle value and limit.
By their numbers in this assay, from the lowest: compounds 1, 3 and 2 (each within the scatter of the next, the first and the last beyond it).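

Within the data shown here, this is the first change in a single place, and it does not bring stronger inhibition. For compound 4, this assay gives only a limit, not a number: the limit of > 200000 nM in this assay, at which 1 of the 4 values shown sits. Nitro in place of dimethylsulfamoyl on this aromatic carbon, meta to a group of 9 heavy atoms, gives an at least 1.8-fold higher number from compound 3 to compound 4 (0.25 log units; that floor lies within the scatter), so the two compounds cannot be told apart on the floor alone, though the true gap could be larger.

From the compounds shown here alone, whether any group on this carbon can give stronger inhibition remains open, since a single swap between two weak compounds says little about the position as a whole. An amine or a carboxylic acid at the same place would test this, and the compounds shown give no value for either.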